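The source may report more compounds than this note shows. Statements on the series, on what has been measured and on what is new or still open speak of the compounds shown alone.

Working notes on the series.

Compound 1 `C=C1CC[C@@H]2[C@](C)(CO)[C@H](O)CC[C@@]2(C)[C@@H]1C/C=C1/C(=O)OC[C@H]1OC(=O)CSc1ccc(C)cc1` and compound 2 `C=C1CC[C@@H]2[C@](C)(CO)[C@H](O)CC[C@@]2(C)[C@@H]1C/C=C1/C(=O)OC[C@H]1OC(=O)CSc1ccc(F)cc1` share one core; compound 3 `C=C1CC[C@@H]2[C@](C)(CO)[C@H](O)CC[C@@]2(C)[C@@H]1C/C=C1/C(=O)OC[C@H]1OC(=O)CCCSc1ccc(C)cc1` and the as yet unmeasured compound 4 `C=C1CC[C@@H]2[C@](C)(CO)[C@H](O)CC[C@@]2(C)[C@@H]1C/C=C1/C(=O)OC[C@H]1OC(=O)CCCSc1ccc(F)cc1` share a second. The two cores differ as described in 2-((4-methylphenyl)sulfanyl)ethyl in place of (4-methylphenyl)sulfanyl on a saturated chain carbon bound to a carbonyl carbon. In a functional assay on PC-3 cells (Homo sapiens) for inhibition, read by MTT assay, with a stated time of 48 h (a lower number here means a stronger inhibitor, a higher number a weaker inhibitor), compound 1 gives 27000 nM, compound 2 gives 14000 nM and compound 3 gives 16000 nM.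

The change fluoro in place of methyl on an aromatic carbon is the same change as fluoro in place of methyl on an aromatic carbon, made on the other core, and both places read the same. Measured once, it produced a 1.9-fold lower number from compound 1 to compound 2 (0.29 log units; within the scatter). Within this set no change moves a value beyond the scatter.

For the measured compounds named here, for compound 4 a step of about the same size as a 1.9-fold lower number from compound 1 to compound 2 (0.29 log units; within the scatter) is expected, namely a 1.6-fold lower number from compound 3 to compound 4 (0.20 log units; within the scatter), resting on the single observed pair of compound 1 and compound 2. Compound 4 is accordingly estimated at 10000 nM, with a range of 4500 nM to 25000 nM.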

Compound 4, half-maximal inhibitory concentration: 12000 nM
Estimate against measurement, compound 4: 1.2-fold (0.08 log units) below, and the stated range covers the measured number.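

In this assay, fluoro in place of methyl on an aromatic carbon reads alike on the two cores: the same change on two cores in this assay, a 1.9-fold lower number (0.29 log units; within the scatter) from compound 1 to compound 2 and a 1.3-fold lower number (0.12 log units; within the scatter) from compound 3 to compound 4, 1.4-fold (0.16 log units) apart, within the scatter of two such steps. The new step, a 1.3-fold lower number from compound 3 to compound 4 (0.12 log units; within the scatter), therefore agrees with the earlier one, and no difference between the cores can be detected for this change. This does not show a real effect of the change itself, as each step lies within the scatter and rests on a single pair; a 1.2-fold lower number from compound 2 to compound 4 (0.07 log units; within the scatter) also lies within it, and only a 2.3-fold lower number from compound 1 to compound 4 (0.35 log units; beyond the scatter), with both places changed at once, passes it.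

Open, on these data alone, is whether the same agreement holds for other groups on that aromatic carbon, such as chloro or methoxy, or on a core with a longer chain.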